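Chlorobenzyl ring position across two amide cores

The compounds below may be only part of what the source reports. "The series", "measured", "known", "first", "only" and "open" are said of these compounds alone.

Four compounds of one series share a thioether-linked chlorobenzyl group and differ in the core and in where the chlorine sits on that benzyl ring. Compound 1 `CC1=C(C(=O)Nc2ccc(Br)cc2)C(c2ccc(Cl)cc2Cl)N=C(SCc2ccccc2Cl)N1` carries a 2-chlorophenyl on a saturated chain carbon bound to a sulfur; in a functional assay on the whole organism (artery, strain albino) with Rattus norvegicus as the target, with a stated time of 900 min, at a dose of 10 mg/kg by the oral route (a higher number here means more inhibition at the dose given (going by the name of the read-out), a lower number less inhibition), compound 1 gives 16.4%. Compound 2 `CC1=C(C(=O)Nc2ccc(Br)cc2)C(c2ccc(Cl)cc2Cl)N=C(SCc2cccc(Cl)c2)N1` is its partner with the chlorine moved, described as 3-chlorophenyl in place of 2-chlorophenyl on a saturated chain carbon bound to a sulfur. In this assay compound 2 gives 7.2%, so the step of a number 9.2 percentage points lower from compound 1 to compound 2 (within the scatter) stays inside the scatter of the method and no direction is read from it.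

Compound 3 `CC1=C(C(=O)Nc2ccc([N+](=O)[O-])cc2)C(c2ccc(Br)cc2)N=C(SCc2ccccc2Cl)N1` has a different core; the difference between the two cores is not broken down here. In this assay compound 3 gives 4.1%, which sits within the scatter of compound 2 and beyond it only against compound 1.

Compound 4 `CC1=C(C(=O)Nc2ccc([N+](=O)[O-])cc2)C(c2ccc(Br)cc2)N=C(SCc2cccc(Cl)c2)N1` has not been measured in this assay. It relates to compound 3 as compound 2 does to compound 1, the same change, (3-chlorophenyl in place of 2-chlorophenyl on a saturated chain carbon bound to a sulfur), at the same place. Because the step of a number 9.2 percentage points lower from compound 1 to compound 2 (within the scatter) did not leave the scatter, the step from compound 3 to compound 4 is expected to be small as well, a number 2.1 percentage points lower from compound 3 to compound 4 (within the scatter), with the read-out of compound 3 already near the floor of the scale. For compound 4 the estimate in this assay is 2%, within a range from -8% to 12%.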

Compound 4, a percentage reported as inhibition, in the whole organism at one dose (the size of the read-out at that dose, not a potency): 2.6%
For compound 4 the middle estimate is 0.6 percentage points below the measured one, within the range that was stated.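

In this assay the change from 2-chlorobenzyl to 3-chlorobenzyl on the core of compound 3 gives a number 1.5 percentage points lower from compound 3 to compound 4 (within the scatter), so no direction is read from it on this core either. Set beside the same change on the core of compound 1, the new step does not differ from the earlier one: the same change on two cores in this assay, a number 9.2 percentage points lower (within the scatter) from compound 1 to compound 2 and a number 1.5 percentage points lower (within the scatter) from compound 3 to compound 4, 7.7 percentage points apart, within the scatter of two such steps. Going by these compounds alone, this shows only that the change gave no step beyond the scatter on either core; it does not show that the change is without effect in general or that a direction carries from one core to the other, and with compound 3 at 4.1% there is little room for a downward step to show on that core.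

Open, from the compounds shown here alone, is whether a longer chain on the sulfur in place of the chlorobenzyl group, or an amine or a carboxylic acid on the benzyl ring in place of the chlorine, would give a step beyond the scatter on either core. The two cores differ in more than one place, and the compounds shown do not separate those differences, so what each part of the core contributes to the read-out also remains open.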